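The source may report more compounds than this note shows. Statements on the series, on what has been measured and on what is new or still open speak of the compounds shown alone.

Compound 1 `CCOC(=O)c1c(-c2cccc([N+](=O)[O-])c2)[nH]c2cc(OC)ccc2c1=O` gives > 21500 nM
Compound 2 `CCOC(=O)c1c(-c2cc(F)cc(OC)c2)[nH]c2cc(OC)c(Cl)cc2c1=O` gives > 21500 nM
Compound 3 `COc1cc2[nH]c(-c3cccc(Oc4ccccc4)c3)c(C(=O)NCCN3CCCC3)c(=O)c2cc1F` gives > 21500 nM

All three readings come from an ADME assay on Raji cells (Homo sapiens) for cytotoxicity, read by luminescence, with a stated time of 72 h (on this read-out lower numbers stand for an effect already at smaller amounts and higher numbers for an effect only at larger amounts of compound), and none of them is a number: the series shows only the limit of > 21500 nM in this assay, at which 3 of the 3 values shown sit, and no graded value. Compound 3 stands there as well, with > 21500 nM as a limit of the assay.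

Compound 4 (`COCCOC(=O)c1c(-c2cccc(Oc3ccccc3)c2)[nH]c2cc(OC)c(F)cc2c1=O`) departs from compound 3 in one place. The change is 2-methoxyethoxy in place of (2-(pyrrolidin-1-yl)ethyl)amino on a carbonyl carbon and it puts 2-methoxyethoxy in place of (2-(pyrrolidin-1-yl)ethyl)amino on a carbonyl carbon. Among the compounds with values here, it turns the amide of compound 3 into an ester, and no measured pair shows such a step directly. Compound 2, also an ester, gives > 21500 nM as its limit and so offers no sign of an effect at the amounts tested. No change beyond the usual scatter is therefore expected, and a step that the limit leaves unreadable from compound 3 to compound 4 is the estimated step. Compound 4 is expected near 25000 nM with an estimated range from 12000 nM to 50000 nM and the assay will probably report only a limit.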

Compound 4, half-maximal effective concentration: > 21500 nM
Compound 4 gave a limit, no number (the forecaster's own chance of this, stated with the estimate: 85%); the middle value does not contradict the limit.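

The step from compound 3 to compound 4 cannot be read in this assay, because both values are limits and not numbers: the limit of > 21500 nM in this assay, at which 4 of the 4 values shown sit.

The compounds shown leave open whether any change on the shared core would give a graded value in this assay at all.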